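Reversed alkyl amide on the pyrazole of compound 2

This account rests on a few compounds, and the source may have more. Where it says the series, first, only, none or still open, it means among the compounds named here.

Of the compounds shown here, three that share one core have been measured in an assay on CHO-K1 cells for displacement of a labelled ligand from prostaglandin E2 receptor EP1 subtype (Homo sapiens); on this read-out higher numbers stand for weaker inhibition and lower numbers for stronger inhibition. Compound 1 `Cc1cc(C(N)=O)nn1Cc1cc(Cl)ccc1OCc1ccccc1` gives 126 nM. Compound 2 `Cc1cc(C(=O)Nc2ccccc2)nn1Cc1cc(Cl)ccc1OCc1ccccc1` gives 39.8 nM, and compound 3 `Cc1cc(NC(=O)CC(C)(C)C)nn1Cc1cc(Cl)ccc1OCc1ccccc1` gives 10 nM. Compound 2 thus stands second highest of the three numbers: its nearest neighbour is compound 1, with a 3.2-fold lower number from compound 1 to compound 2 (0.50 log units; beyond the scatter) separating them, and its furthest is compound 3, reached by a 4.0-fold lower number from compound 2 to compound 3 (0.60 log units; beyond the scatter).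

Compound 4 `Cc1cc(NC(=O)CC2CCCCC2)nn1Cc1cc(Cl)ccc1OCc1ccccc1` has not yet been measured. It differs from compound 2 in one place: ((cyclohexylmethyl)carbonyl)amino in place of phenylcarbamoyl on an aromatic carbon

Among the compounds with values here, the step that bears most directly on this change is the one already seen from compound 2 to compound 3, a 4.0-fold lower number from compound 2 to compound 3 (0.60 log units; beyond the scatter), where phenylcarbamoyl also gave way to an alkyl-bearing acylamino group, there (neopentylcarbonyl)amino. The incoming ((cyclohexylmethyl)carbonyl)amino group is of the same kind, with a six-membered non-aromatic ring in place of the branched chain. The step from compound 1 to compound 3, a 13-fold lower number from compound 1 to compound 3 (1.10 log units; beyond the scatter), points the same way. Compound 4 is therefore expected to show a step of a 3.3-fold lower number from compound 2 to compound 4 (0.52 log units; beyond the scatter) in this assay, a modest lowering of the number. The estimate for compound 4 is 12 nM, with a range from 4 nM to 35 nM.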

Compound 4, half-maximal inhibitory concentration: 6.31 nM
Compound 4: the middle estimate sits 1.9-fold (0.28 log units) above what was measured; the range from low to high includes it.
By their numbers in this assay, from the lowest: compounds 4 and 3 (each within the scatter of the next); then compound 2; then compound 1.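

In this assay, a second alkyl-bearing acylamino group on this aromatic carbon gives a 6.3-fold lower number from compound 2 to compound 4 (0.80 log units; beyond the scatter) and a 20-fold lower number from compound 1 to compound 4 (1.30 log units; beyond the scatter) so the lowering seen with compound 3 is not confined to the (neopentylcarbonyl)amino group. Cyclohexyl in place of tert-butyl on the saturated chain carbon gives a 1.6-fold lower number from compound 3 to compound 4 (0.20 log units; within the scatter) so compounds 3 and 4 cannot be told apart, and either a one-ring or a branched end on this chain fits the values printed for these two compounds. No data shown here speak to the reason for any of these steps.

The change from compound 2 to compound 4 alters both the direction of the amide and the ring, and these compounds do not separate the two, which a (phenylacetyl)amino group on the same carbon would help to do. Also open, as far as these compounds go, is how far this position reaches, for instance whether a longer chain between the carbonyl and the cyclohexyl ring, or a carboxylic acid or an amine on that ring, would keep the number this low.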